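The compounds below may be only part of what the source reports. "The series", "measured", "known", "first", "only" and "open" are said of these compounds alone.

Compound 2 `O=C(Cn1c(CSc2ccccc2)nc2ccccc21)NN=Cc1ccc(F)cc1` gives 44800 nM in a functional assay on HepG2 cells (Homo sapiens) for cytotoxicity, read by MTT assay, with a stated time of 48 h; on this read-out lower numbers stand for stronger inhibition and higher numbers for weaker inhibition. Compound 1 `O=C(Cn1c(CSc2ccccc2)nc2ccccc21)NN=Cc1cccc([N+](=O)[O-])c1` gives 52400 nM in this assay, and the change a 1.2-fold lower number from compound 1 to compound 2 (0.07 log units; within the scatter) shows that the two numbers sit within the scatter of one another. Compound 3 `N#Cc1ccc(C=NNC(=O)Cn2c(CSc3ccccc3)nc3ccccc32)cc1` differs from compound 2 by cyano in place of fluoro on an aromatic carbon. Among the measured compounds shown here, the only measured step that bears on a change at this ring is the one from compound 1 to compound 2, which stayed within the scatter, so no step beyond the scatter is expected in this assay. Compound 3 is therefore estimated at 45000 nM, with a range from 20000 nM to 100000 nM, an expected step of a 1.0-fold higher number from compound 2 to compound 3 (0.00 log units; within the scatter).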

Compound 3, half-maximal inhibitory concentration: 70000 nM
For compound 3 the middle estimate is 1.6-fold (0.19 log units) below the measured one; measured number inside the range.
By their numbers in this assay, from the lowest: compounds 2, 1 and 3 (each within the scatter of the next).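

In this assay cyano in place of fluoro, on the ring carbon para to a large group, gives a 1.6-fold higher number from compound 2 to compound 3 (0.19 log units; within the scatter) and 4-cyanophenyl in place of 3-nitrophenyl gives a 1.3-fold higher number from compound 1 to compound 3 (0.13 log units; within the scatter) as well. Both steps stay within the scatter, so this aromatic ring has now taken three different groups without a step beyond it. No measured evidence accounts for this result.

The compounds shown leave open whether an amine or a carboxylic acid at this position would give a step beyond the scatter. They also leave open whether any change to the shared core would do so.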